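This account rests on a few compounds, and the source may have more. Where it says the series, first, only, none or still open, it means among the compounds named here.

Measured so far:
Compound 1, `C=CS(=O)(=O)NC/C=C/c1cc(OC)cc(O)c1C(=O)OC(C)C`: 13.9%
Compound 2, `COc1cc(O)c(C(=O)OCC(C)c2ccccc2)c(/C=C/CN2C(=O)C=CC2=O)c1`: 0%

In an assay on isolated protein for inhibition of MAP kinase-interacting serine/threonine-protein kinase 2 (Homo sapiens), tested at 10 uM (a higher number here means more inhibition at the concentration tested (going by the name of the read-out), a lower number less inhibition), compound 2 gives the lowest of the two numbers; the nearest is compound 1, whose value is higher by a gap beyond the usual scatter. Compound 3, `COc1cc(O)c(C(=O)OC(C)C)c(/C=C/CN2C(=O)C=CC2=O)c1`, has not yet been measured. It differs from compound 2 in one place: isopropyl in place of 2-phenylpropyl on an oxygen next to a carbonyl group. Among the compounds with values here, no measured pair here differs in this one place alone, so the size of this step has no direct precedent. Compound 1 also carries isopropyl on an oxygen next to a carbonyl group, but it differs from compound 3 elsewhere too, so its value is not a direct guide. The step in this assay is expected to be small, upward if anything, and probably within the scatter: a number 6 percentage points higher from compound 2 to compound 3 (within the scatter). For compound 3 the estimated inhibition is 6%, with a range from 0% to 20%.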

Compound 3, a percentage reported as inhibition, at one concentration (the size of the read-out at that concentration, not a potency): 4.1%
Estimate against measurement, compound 3: 1.9 percentage points above; the range from low to high includes it.
By their numbers in this assay, from the lowest: compounds 2, 3 and 1 (each within the scatter of the next, the first and the last beyond it).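

Within this assay, putting isopropyl in place of 2-phenylpropyl on an oxygen next to a carbonyl group gives a number 4.1 percentage points higher from compound 2 to compound 3 (within the scatter) and stays within the scatter, so this read-out does not separate the two groups at this position, even though one carries a six-membered aromatic ring and the other has no ring. Placing the group with a five-membered non-aromatic ring on the saturated chain carbon, in place of the ringless group containing sulfur, gives a number 9.8 percentage points lower from compound 1 to compound 3 (within the scatter) and also stays within the scatter. Nothing measured here bears on why these steps are this size.

A longer straight chain or a chain carrying an amine on that oxygen could still behave differently. As far as these compounds go, with a single tested concentration, potency also remains unknown.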